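Working notes: 4-methylphenyl in place of methyl

The source may report more compounds than this note shows. Statements on the series, on what has been measured and on what is new or still open speak of the compounds shown alone.

Measured so far in a functional assay on MCF7 cells (Homo sapiens) for cytotoxicity, read by MTT assay, with a stated time of 48 h; on this read-out lower numbers stand for stronger inhibition and higher numbers for weaker inhibition
- compound 1 `COc1cc(COCc2cn(Cc3cc(C)cnc3Cl)nn2)cc(OC)c1OC` gives 67400 nM
- compound 2 `COc1cc(-c2cc(COCc3cn(Cc4cc(C)cnc4Cl)nn3)on2)cc(OC)c1OC` gives 194000 nM

Compound 1 holds the lower of the two numbers in this assay and so stands as the stronger of this pair. The gap up to compound 2 lies beyond the usual scatter. For the measured compounds named here, with only two measured compounds, and no single-place change between them, the series offers no direct precedent for the next step.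

Compound 3 `COc1cc(COCc2cn(Cc3cc(-c4ccc(C)cc4)cnc3Cl)nn2)cc(OC)c1OC` has not yet been measured. Against compound 1 it carries 4-methylphenyl in place of methyl on an aromatic carbon, para to a chloro group (4-methylphenyl in place of methyl on an aromatic carbon). The change keeps the count of hydrogen-bond donors and acceptors unchanged, and the rest of the core of compound 1 stays as it is. A small step toward a lower number is expected, only modestly beyond the scatter, and with wide uncertainty in either direction. An estimated 2.2-fold lower number from compound 1 to compound 3 (0.35 log units; beyond the scatter) is expected in this assay on this basis. Compound 3 is estimated at 30000 nM (expected range 9000 nM to 100000 nM).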

Compound 3, half-maximal inhibitory concentration: 146000 nM
Estimate against measurement, compound 3: 4.9-fold (0.69 log units) below; measured number outside the range, above it.
By their numbers in this assay, from the lowest: compound 1; then compounds 3 and 2 (each within the scatter of the next).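

In this assay, for the compounds shown here, the first single-place step shows that 4-methylphenyl in place of methyl, on the aromatic carbon para to a chloro group, gives a 2.2-fold higher number from compound 1 to compound 3 (0.34 log units; beyond the scatter), a modest move toward weaker inhibition. This position therefore responds to the change from a single carbon to a six-membered aromatic ring of carbon only, even though the counts of hydrogen-bond donors and acceptors stay unchanged, and the larger group does not bring a lower number here. Nothing measured among the compounds shown accounts for the direction of this step.

Going by these compounds, it remains open whether the higher number follows from the phenyl ring itself or from its methyl, and whether an unsubstituted phenyl, an amine or a carboxylic acid at this place would give a number nearer to compound 1 or to compound 3. On these data alone, it also remains open whether the same 4-methylphenyl change would give a step of similar size on the core of compound 2.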